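Compound 3 to compound 4: clearance notes

This account rests on a few compounds, and the source may have more. Where it says the series, first, only, none or still open, it means among the compounds named here.

Values in an ADME assay on microsomes from liver (Homo sapiens) for metabolic stability, read by LC-MS, with a stated time of 30 min, tested at 1 uM (a lower number here means slower removal, a higher number faster removal of the compound), follow.
Compound 1 `COc1ccc(-c2ccc3nnc([C@@H](C)c4ccc5ncccc5c4)n3n2)cc1C` gives 304 mL.min-1.g-1
Compound 2 `C[C@@H](c1ccc2ncccc2c1)c1nnc2ccc(-c3ccccc3C#N)nn12` gives 23.1 mL.min-1.g-1
Compound 3 `CNC(=O)c1ccc(-c2ccc3nnc([C@@H](C)c4ccc5ncccc5c4)n3n2)cc1` gives 12.2 mL.min-1.g-1

Compound 3 stands at the low end of these numbers, with a 1.9-fold lower number from compound 2 to compound 3 (0.28 log units; within the scatter) as its nearest step and a 25-fold lower number from compound 1 to compound 3 (1.40 log units; beyond the scatter) as its furthest. Compound 4 `CCS(=O)(=O)c1ccc(-c2ccc3nnc([C@@H](C)c4ccc5ncccc5c4)n3n2)cc1` differs from it as follows: ethylsulfonyl in place of methylcarbamoyl on an aromatic carbon. The ethylsulfonyl group enters para to a large group. Among the measured compounds shown here, no measured step makes this exact exchange. Both large steps leave the 4-methoxy-3-methylphenyl group, the other being a 13-fold lower number from compound 1 to compound 2 (1.12 log units; beyond the scatter). The exchange between two replacement groups gave only a 1.9-fold lower number from compound 2 to compound 3 (0.28 log units; within the scatter), so no change beyond the scatter is expected here. The estimated step is a 1.5-fold higher number from compound 3 to compound 4 (0.17 log units; within the scatter). The estimate for compound 4 is 18 mL.min-1.g-1, with an expected range of 7 mL.min-1.g-1 to 45 mL.min-1.g-1.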

Compound 4, intrinsic clearance in microsomes: 10.4 mL.min-1.g-1
Beside the measured number, compound 4's estimate is 1.7-fold (0.24 log units) above it; the range from low to high includes it.
By their numbers in this assay, from the lowest: compounds 4, 3 and 2 (each within the scatter of the next, the first and the last beyond it); then compound 1.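

In this assay, ethylsulfonyl in place of methylcarbamoyl on the aromatic carbon para to a large group gives a 1.2-fold lower number from compound 3 to compound 4 (0.07 log units; within the scatter). This pair shows that a low number at this position does not require the hydrogen-bond donor of methylcarbamoyl, since ethylsulfonyl has none. No measurement at hand explains why the two groups read alike.

Open, going by these compounds, is whether an amine, a carboxylic acid or a longer chain at this position would read as low as compound 3 and compound 4. Also open, on these data alone, is whether 4-methoxyphenyl would read nearer compound 1 or compound 3.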